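Fluorine placement at the aryl ketone end of the series

This account rests on a few compounds, and the source may have more. Where it says the series, first, only, none or still open, it means among the compounds named here.

Measured so far:
compound 1 `O=C(/C=C/c1ccc2c(c1)B(O)OC2)c1ccc(F)cc1` — 2800 nM
compound 2 `O=C(/C=C/c1ccc2c(c1)B(O)OC2)c1ccc(C(F)(F)F)cc1` — 6300 nM
compound 3 `O=C(/C=C/c1ccc2c(c1)B(O)OC2)c1ccc([N+](=O)[O-])cc1` — 9100 nM

In a functional assay on HCT-116 cells (Homo sapiens) for cytotoxicity, read by MTT assay, with a stated time of 48 h (on this read-out lower numbers stand for stronger inhibition and higher numbers for weaker inhibition), compound 1 gives the lowest of the three numbers. Its nearest neighbour is compound 2, and the step of a 2.3-fold higher number from compound 1 to compound 2 (0.35 log units; beyond the scatter) lies beyond the scatter; the furthest is compound 3, reached by a 3.3-fold higher number from compound 1 to compound 3 (0.51 log units; beyond the scatter). Between the two weaker compounds the step of a 1.4-fold higher number from compound 2 to compound 3 (0.16 log units; within the scatter) stays within the scatter, so their numbers cannot be ordered.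

Compound 4 `O=C(/C=C/c1ccc2c(c1)B(O)OC2)c1ccccc1F` has not been measured in this assay. The change from compound 1 is 2-fluorophenyl in place of 4-fluorophenyl on a carbonyl carbon: the same atoms, joined differently. Going by the values given here, none of the measured steps bears on this change directly, since each of them swaps the group on the aromatic carbon while keeping its position; no measured pair moves a fluorine around the ring. What the measured steps do show is that alterations at this end of the shared core shift the number only modestly, never by more than the step from compound 1 to compound 3.

Among the compounds with values here, with no direct precedent, the expectation for compound 4 is a step of a 1.3-fold higher number from compound 1 to compound 4 (0.10 log units; within the scatter), not beyond the scatter. Compound 4 is therefore estimated at 3500 nM, with a range from 1400 nM to 9000 nM.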

Compound 4, half-maximal inhibitory concentration: 4200 nM
Beside the measured number, compound 4's estimate is 1.2-fold (0.08 log units) below it; the measured number falls inside the stated range.
By their numbers in this assay, from the lowest: compounds 1, 4, 2 and 3 (each within the scatter of the next, the first and the last beyond it).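

Compound 4 gives the series its first read on where the fluorine sits rather than which group is present. In this assay the step of a 1.5-fold higher number from compound 1 to compound 4 (0.18 log units; within the scatter) means that 2-fluorophenyl and 4-fluorophenyl on the carbonyl carbon cannot be told apart, so this rearrangement of the same atoms produces no readable change. By contrast, the readable changes from compound 1 so far, a 2.3-fold higher number from compound 1 to compound 2 (0.35 log units; beyond the scatter) and a 3.3-fold higher number from compound 1 to compound 3 (0.51 log units; beyond the scatter), both replace the fluoro group itself, although two such steps and one positional pair are too few to make this a general pattern. No supporting data bear on the reason for this result.

Only fluorine has been moved around the ring in the compounds shown, so it remains open whether trifluoromethyl or nitro would also tolerate the same move in this assay. Also open is how an amine, a carboxylic acid or a methoxy group would read in place of the fluoro group, as none of these appears among the four compounds shown.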